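The compounds below may be only part of what the source reports. "The series", "measured", "known", "first", "only" and "open" are said of these compounds alone.

Compounds measured in an assay on membranes from Sf9 cells for displacement of a labelled ligand from histamine H2 receptor (Homo sapiens), read by scintillation counting, with a stated time of 60 min; on this read-out higher numbers stand for weaker inhibition and lower numbers for stronger inhibition:

- compound 1 `N/C(=N\C(=O)NCc1ccccc1)NC1CCc2nc(N)sc2C1` gives 513 nM
- compound 2 `Cc1nc(N)sc1CCCN/C(N)=N/C(=O)N[C@@H](C)c1ccccc1` gives 51.3 nM
- compound 3 `Cc1nc(N)sc1CCCN/C(N)=N/C(=O)NC(C)c1ccccc1F` gives 28.8 nM

Compound 3 has the lowest number of the three in this assay. The nearest is compound 2, whose number is higher by an amount that stays within the usual scatter of repeated measurements, so the two cannot be ordered. The furthest is compound 1, whose number is higher by an amount well beyond the scatter, so compound 1 is the weaker of that pair.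

Compound 4 `Cc1nc(N)sc1CCCN/C(N)=N/C(=O)NC(C)c1cccc(F)c1` has not yet been measured. It differs from compound 3 in one place: 3-fluorophenyl in place of 2-fluorophenyl on a saturated chain carbon bound to an amide-type nitrogen and a saturated chain carbon. The two compounds have the same atoms joined differently. For the measured compounds named here, no pair of measured compounds shows this change, so there is no measured step to lean on; the expectation rests only on the values of compounds 2 and 3, which are within the scatter of each other despite their differing phenyl groups. The step from compound 3 to compound 4 in this assay is expected to be small, in either direction, or none beyond the scatter. Compound 4 is therefore expected to give about 35 nM in this assay, within 12 nM to 100 nM, an expected step of a 1.2-fold higher number from compound 3 to compound 4 (0.08 log units; within the scatter).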

Compound 4, inhibition constant: 2.04 nM
For compound 4 the middle estimate is 17-fold (1.23 log units) above the measured one; the whole stated range lies above it.
By their numbers in this assay, from the lowest: compound 4; then compounds 3 and 2 (each within the scatter of the next); then compound 1.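

In this assay, for the compounds shown here, 3-fluorophenyl in place of 2-fluorophenyl on a saturated chain carbon bound to an amide-type nitrogen and a saturated chain carbon gives a 14-fold lower number from compound 3 to compound 4 (1.15 log units; beyond the scatter), a large step, and the first that can be read at this position, since the earlier compounds offered no pair differing in one place. The two groups have the same heavy atoms, the same aromatic ring and the same counts of hydrogen-bond donors and acceptors, so this position responds strongly to where the fluorine sits on the phenyl ring, even though the group's composition stays the same. Nothing among the available data bears on why the placement matters so much.

Going by these compounds, whether the same response holds for 4-fluorophenyl, 3-chlorophenyl or 3-methoxyphenyl on this carbon stays open, so the step cannot yet be assigned to fluorine specifically or to any group at that ring position. Also open, on these data alone, are which mirror form of compound 4 carries its value and whether the step survives with a longer chain in place of the methyl group on this carbon.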